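Ethoxy on the distal ring of compound 3

The compounds below may be only part of what the source reports. "The series", "measured", "known", "first", "only" and "open" are said of these compounds alone.

Compound 1 `Oc1ccccc1CNc1ccccc1` and compound 2 `Oc1ccccc1CNc1ccc(N2CCNCC2)cc1` have no number: in a functional assay on Jurkat cells (Homo sapiens) for activation, with a stated time of 24 h (a lower number here means that less compound is needed, a higher number that more compound is needed for the effect), compound 1 gives "not active" (no number reported), and compound 2 gives "not active" (no number reported). Among the measured compounds shown here, compound 3 `Oc1ccccc1CNc1ccc(-c2ccccc2)cc1` is the only member of the series with a measured value; in this assay compound 3 gives 1820 nM. Compound 4 `CCOc1ccc(-c2ccc(NCc3ccccc3O)cc2)cc1` has not yet been measured. It differs from compound 3 by ethoxy in place of hydrogen on an aromatic carbon, para to a large group. For the measured compounds named here, no measured pair tells what such a change does, so the direction is open; the step of a 1.5-fold lower number from compound 3 to compound 4 (0.18 log units; within the scatter) is expected to stay close to the scatter, with a small shift toward less compound needed as the more likely side. Compound 4 is therefore estimated at 1200 nM in this assay, within a range from 300 nM to 5000 nM.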

Compound 4, half-maximal effective concentration: 520 nM
For compound 4 the middle estimate is 2.3-fold (0.36 log units) above the measured one; the measured number falls inside the stated range.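

Ethoxy in place of hydrogen on an aromatic carbon, para to a large group, is the first change in the series with a readable effect: in this assay it gives a 3.5-fold lower number from compound 3 to compound 4 (0.54 log units; beyond the scatter). This position therefore accepts a group larger than hydrogen, and the number moves toward less compound needed. Nothing at hand accounts for this step.

On these data alone, this rests on a single pair, so it remains open whether the shift belongs to ethoxy specifically. Methoxy, a longer alkoxy chain, fluorine or an amine at this position would test that.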